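Nitro to Methyl: What the Cell Assay May Show

This account rests on a few compounds, and the source may have more. Where it says the series, first, only, none or still open, it means among the compounds named here.

Measured in an ADME assay on Vero cells (Chlorocebus sabaeus) for cytotoxicity, read by neutral red uptake, tested at 197 ug/mL; a lower number here means a stronger effect, a higher number a weaker effect of the compound at the concentration tested:
compound 1 `COc1ccc(C2SCC(=O)N2CCN2CCCCC2)cc1`: 87%
compound 2 `O=C1CSC(c2cccc(Cl)c2)N1CCN1CCCCC1`: 77%
compound 3 `O=C1CSC(c2ccc([N+](=O)[O-])cc2)N1CCN1CCCCC1`: 72%

Compound 3 carries the lowest of the three numbers in this assay. Compound 2 sits within the usual scatter of it, so the two cannot really be told apart, whereas compound 1 stands beyond the scatter above compound 3.

Compound 4 `Cc1ccc(C2SCC(=O)N2CCN2CCCCC2)cc1` differs from compound 3 by methyl in place of nitro on an aromatic carbon. Within the data shown here, only one measured step touches the nitro group: a number 15 percentage points lower from compound 1 to compound 3 (beyond the scatter), which put the nitro in place of a methoxy and lowered the number by a modest but real amount. The change to compound 4 removes the nitro again, though what enters is a methyl rather than a methoxy. Compound 2, carrying a chloro instead, gives a number close to compound 3, which shows that a small group at this position does not by itself push the value far from where compound 3 lies.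

Taken together, a small rise in this assay is expected, on the order of a number 8 percentage points higher from compound 3 to compound 4 (within the scatter), most likely not beyond the scatter. Compound 4 is therefore estimated at 80%, within a range of 68% to 92%.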

Compound 4, a percentage reported as activity, at one concentration (the size of the read-out at that concentration, not a potency): 85%
Compound 4: the middle estimate sits 5 percentage points below what was measured; measured number inside the range.
By their numbers in this assay, from the lowest: compounds 3, 2, 4 and 1 (each within the scatter of the next, the first and the last beyond it).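

Within this assay, putting methyl in place of nitro on the aromatic carbon para to a large group gives a number 13 percentage points higher from compound 3 to compound 4 (beyond the scatter) and this second step beyond the scatter shows that the lower number of compound 3 holds against methyl as well as against methoxy. Methyl and methoxy at this place cannot be told apart, with a number 2 percentage points lower from compound 1 to compound 4 (within the scatter) and no step beyond the scatter between them, while a number 8 percentage points higher from compound 2 to compound 4 (within the scatter) also stays within the scatter, so compound 2, which is within the scatter of both compound 3 and compound 4, cannot be placed with either. Nothing available explains why the nitro compound differs from the other two at this position.

The compounds shown leave open whether the lower number belongs to nitro alone or would also appear with another group on that aromatic carbon, such as an amine, a carboxylic acid or a chloro. They also leave open whether a longer chain there would stay level with methyl and methoxy or fall toward nitro.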